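This account rests on a few compounds, and the source may have more. Where it says the series, first, only, none or still open, it means among the compounds named here.

Measured in a functional assay on A549 cells (Homo sapiens) for antiproliferative activity, read by MTT assay, with a stated time of 72 h; on this read-out higher numbers stand for weaker inhibition and lower numbers for stronger inhibition:

Compound 1 `COc1cc(-n2ncnc2-c2ccc(C)cc2)cc(OC)c1OC`: 1100 nM
Compound 2 `COc1cc(-c2ncnn2-c2cccc(N)c2)cc(OC)c1OC`: > 10000 nM, a limit of the assay
Compound 3 `COc1cc(-c2ncnn2-c2ccc([N+](=O)[O-])cc2)cc(OC)c1OC`: > 10000 nM, a limit of the assay

Going by the values given here, compound 1 holds the only actual number of the three, and the other two results are limits: the limit of > 10000 nM in this assay, at which 2 of the 3 values shown sit.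

Compound 4 `COc1cc(-n2ncnc2-c2ccc(OC(C)C)cc2)cc(OC)c1OC` carries isopropoxy in place of methyl on an aromatic carbon, para to a large group (isopropoxy in place of methyl on an aromatic carbon). Among the compounds with values here, no measured pair differs in one place alone, so the data offer no direct guide to this change. Starting from compound 1 at 1100 nM, no step beyond the scatter is expected in this assay, though with wide uncertainty. The expected change is a 1.1-fold lower number from compound 1 to compound 4 (0.04 log units; within the scatter). For compound 4 the estimated value is 1000 nM, with an expected range of 120 nM to 8000 nM.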

Compound 4, half-maximal inhibitory concentration: > 10000 nM
Compound 4 ended at the assay's limit; the forecaster's own chance of this, stated with the estimate: 15%; middle value at least 10-fold (1.00 log units) away from the limit.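

In this assay compound 4 gives > 10000 nM as a limit of the assay. Isopropoxy in place of methyl on this aromatic carbon, para to a large group, brings an at least 9.0-fold higher number from compound 1 to compound 4 (0.95 log units; beyond the scatter) on this read-out, the first single-place comparison here and evidence that this position does not accept every group without loss. Going by these compounds alone, compound 1 still holds the only actual number: the limit of > 10000 nM in this assay, at which 3 of the 4 values shown sit.

The compounds shown leave open whether methoxy or ethoxy on this carbon would keep a measurable value. As far as these compounds go, the true distance between compound 4 and compound 1 also remains unknown.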